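The source may hold more compounds than are shown below. What is called first, only, known or untested is meant among the compounds shown, and "the series" means these compounds.

In a functional assay on Hep 3B2 cells (Homo sapiens) for antiproliferative activity, read by MTT assay, with a stated time of 24 h, tested at 0.02 ug/mL (on this read-out lower numbers stand for a weaker effect and higher numbers for a stronger effect at the one concentration tested), compound 1 `CCc1ccc2nc(C(=O)Nc3c(F)cc(-c4cccc(F)c4)cc3F)c(C)c(O)c2c1` gives 2.05%, and compound 2 `Cc1c(C(=O)Nc2c(F)cc(-c3cccc(F)c3)cc2F)nc2ccc(OC(F)(F)F)cc2c1O` gives 0.67%. Compound 2 thus stands alongside compound 1, since the step of a number 1.4 percentage points lower from compound 1 to compound 2 (within the scatter) is too small to count as a change. Compound 3 `Cc1c(C(=O)Nc2c(F)cc(-c3cccc(F)c3)cc2F)nc2ccc(C(F)(F)F)cc2c1O` differs from compound 2 in one place: trifluoromethyl in place of trifluoromethoxy on an aromatic carbon. Within the data shown here, the only measured step, a number 1.4 percentage points lower from compound 1 to compound 2 (within the scatter), likewise swapped one group on that same aromatic carbon and stayed within the scatter, so in this assay no step beyond the scatter is expected for compound 3. The estimate for compound 3 is 1.5%, between -5% and 10%. This amounts to an expected step of a number 0.8 percentage points higher from compound 2 to compound 3 (within the scatter).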

Compound 3, a percentage reported as inhibition, at one concentration (the size of the read-out at that concentration, not a potency): 0.06%
Estimate against measurement, compound 3: 1.4 percentage points above; low and high end bracket the measured number.
By their numbers in this assay, from the lowest: compounds 3, 2 and 1 (each within the scatter of the next).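

With ethyl, trifluoromethoxy and trifluoromethyl now compared on this aromatic carbon in this assay, the series shows no separation between them. Trifluoromethyl gives a number 0.6 percentage points lower from compound 2 to compound 3 (within the scatter) when it takes the place of trifluoromethoxy and a number 2 percentage points lower from compound 1 to compound 3 (within the scatter) when it takes the place of ethyl, so losing the oxygen of trifluoromethoxy leaves the reading indistinguishable, with all three compounds near zero at this single concentration. No measurement available here explains these readings. On these data alone, whether an amine or a carboxylic acid on this carbon would give clearly more inhibition stays open. So does how these compounds would compare at other concentrations.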